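Chloro in Place of Fluoro Across Two Related Cores

The source may report more compounds than this note shows. Statements on the series, on what has been measured and on what is new or still open speak of the compounds shown alone.

Compound 1 `Nc1ccccc1NC(=O)c1ccc(CNC(=O)c2n[nH]cc2NC(=O)c2c(F)cccc2Cl)cc1`, in a functional assay on HeLa cells (Homo sapiens) for inhibition, read by CCK-8 assay, with a stated time of 72 h; on this read-out lower numbers stand for stronger inhibition and higher numbers for weaker inhibition: 3270 nM
Compound 2 `Nc1ccccc1NC(=O)c1ccc(CNC(=O)c2n[nH]cc2NC(=O)c2c(Cl)cccc2Cl)cc1`: 1830 nM
Compound 3 `O=C(NO)c1ccc(CNC(=O)c2n[nH]cc2NC(=O)c2ccccc2F)cc1`: 6610 nM

Compound 2 differs from compound 1 by chloro in place of fluoro on an aromatic carbon, a change that gave a 1.8-fold lower number from compound 1 to compound 2 (0.25 log units; within the scatter). Compound 3 carries a different core; the difference between the two cores is not broken down here. Compound 4 `O=C(NO)c1ccc(CNC(=O)c2n[nH]cc2NC(=O)c2ccccc2Cl)cc1` is compound 3 with chloro in place of fluoro on an aromatic carbon. This is the same kind of change as from compound 1 to compound 2, but the surroundings differ: in compound 1 the changed carbon is ortho to a large group and meta to a chloro group, whereas in compound 3 it is only ortho to a large group. Among the measured compounds, compound 3 gives the highest number. For compound 4 a step of a 1.6-fold lower number from compound 3 to compound 4 (0.20 log units; within the scatter) is expected in this assay, resting on compound 3 at 6610 nM and on a 1.8-fold lower number from compound 1 to compound 2 (0.25 log units; within the scatter). Compound 4 is estimated at 4200 nM, likely between 2000 nM and 9000 nM.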

Compound 4, half-maximal inhibitory concentration: 16200 nM
Compound 4: middle estimate off by 3.9-fold (0.59 log units), on the low side; measured number outside the range, above it.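

In this assay, chloro in place of fluoro gave a 2.5-fold higher number from compound 3 to compound 4 (0.39 log units; beyond the scatter), so compound 4 inhibits less strongly than compound 3. The same change therefore did not carry over as a fixed amount between these two settings: the same change on two cores in this assay, a 1.8-fold lower number (0.25 log units; within the scatter) from compound 1 to compound 2 and a 2.5-fold higher number (0.39 log units; beyond the scatter) from compound 3 to compound 4, 4.4-fold (0.64 log units) apart, beyond the scatter of two such steps This does not show that the core alone accounts for the mismatch, since compound 1 also carries a further chloro group on the changed ring, which compound 3 lacks.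

The compounds shown leave open how a methoxy or bromo group at that place would compare on either core. They also leave open how 2-fluorophenyl to 2-chlorophenyl would behave on the core of compound 1 without that further chloro group.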